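Hydroxamic acids on a shared core: hepatocyte clearance

This account rests on a few compounds, and the source may have more. Where it says the series, first, only, none or still open, it means among the compounds named here.

Measured so far:
compound 1, `O=C(CCCCCNc1c(Nc2ccccc2)c(=O)c1=O)NO`, < 4.8 uL/min
compound 2, `C[C@H](Nc1c(NCCCCCC(=O)NO)c(=O)c1=O)c1ccccc1`, < 5 uL/min
compound 3, `CC[C@H](Nc1c(NCCCCCC(=O)NO)c(=O)c1=O)c1ccccc1`, < 5 uL/min

In an ADME assay on cells (Hepatocyte, Homo sapiens) for pharmacokinetics, read by LC-MS, with a stated time of 90 min, tested at 1 uM (a higher number here means faster removal of the compound, a lower number slower removal), compound 1 gives < 4.8 uL/min, a limit of the assay. Compound 2 gives < 5 uL/min, also a limit. Compound 3 gives < 5 uL/min, again a limit. Compound 2 differs from compound 1 by phenyl in place of 1-phenylethyl on a nitrogen on an aromatic ring, and a step that the two limits leave unreadable from compound 1 to compound 2. Compound 3 differs from compound 2 by methyl in place of hydrogen on a saturated chain carbon, two bonds along the chain from an aromatic carbon and a nitrogen on an aromatic ring, and a step that the two limits leave unreadable from compound 2 to compound 3.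

Compound 4, `CC(CCCCC(=O)NO)Nc1c(Nc2ccccc2)c(=O)c1=O`, is not yet measured. It differs from compound 1 by methyl in place of hydrogen on a saturated chain carbon bound to a nitrogen on an aromatic ring and a saturated chain carbon, the same kind of change as that from compound 2 to compound 3, though the place differs: there the carbon is two bonds along the chain from an aromatic carbon and a nitrogen on an aromatic ring, here it is bound to a nitrogen on an aromatic ring and a saturated chain carbon. Since the limit of < 4.8 uL/min in this assay, at which 1 of the 3 values shown sits, and the limit of < 5 uL/min in this assay, at which 2 of the 3 values shown sit, both sit at the assay limit, the step in this assay is expected to be small, about a step that the limit leaves unreadable from compound 1 to compound 4. Compound 4 is estimated at 4 uL/min, between 1 uL/min and 12 uL/min, most likely reported only as a limit.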

Compound 4, intrinsic clearance in a liver preparation (reported as CLH), per the amount of preparation that the assay uses: < 5 uL/min
Compound 4 ended at the assay's limit; the forecaster's own chance of this, stated with the estimate: 65%; the middle value is on the limit's open side.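

For the compounds shown here, compound 1 and compound 4 both give only limits in this assay, and no step between them can be read. The compounds shown leave open how fast any of them is actually removed, and whether the added methyl changes that at all.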